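Rearranging a Side Chain at a Very Low Free Fraction

The source may report more compounds than this note shows. Statements on the series, on what has been measured and on what is new or still open speak of the compounds shown alone.

Only the part of a compound not held by plasma proteins circulates free, and for this pair of compounds that part is small. In an ADME assay on the whole organism (plasma, Mus musculus, strain CD-1) for protein binding, read by LC-MS, with a stated time of 24 h (on this read-out lower numbers stand for a smaller free fraction and higher numbers for a larger free fraction), compound 1 (`Cc1noc(-c2ccc(O[C@H]3CCC[C@H](C(=O)O)C3)cc2)c1COC(=O)N(C)CCC(C)C`) gives 0.004, and compound 2 (`CN(C(=O)OCc1c(-c2ccc(O[C@H]3CCC[C@H](C(=O)O)C3)cc2)cnn1C)C1CCCC1`) gives 0.013. Compound 1 therefore holds the lower of the two numbers, and the gap between them lies beyond the usual scatter of repeated measurements. The two compounds differ in more than one place, so this gap cannot be tied to any single change.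

Compound 3 (`Cc1noc(-c2ccc(O[C@H]3CCC[C@H](C(=O)O)C3)cc2)c1CNC(=O)OCCC(C)(C)C`) keeps the core of compound 1 and alters one group, on a saturated chain carbon bound to an aromatic carbon: a group of 10 heavy atoms (7 carbon, 1 nitrogen, 2 oxygen; no ring) in place of a group of 10 heavy atoms (7 carbon, 1 nitrogen, 2 oxygen; no ring), on a saturated chain carbon bound to an aromatic carbon. The two compounds have the same atoms, joined differently. Among the measured compounds shown here, no measured pair here shows what such a rearrangement does. The expectation rests on compound 1 with its 0.004. The estimated change is a 1.5-fold higher number from compound 1 to compound 3 (0.18 log units; within the scatter), which is expected to stay within the scatter. In this assay, the estimate for compound 3 is 0.006, with an expected range of 0.002 to 0.015.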

Compound 3, unbound fraction: 0.004
Compound 3: middle estimate off by 1.5-fold (0.18 log units), on the high side, and the stated range covers the measured number.
By their numbers in this assay, from the lowest: compounds 1 and 3 (each within the scatter of the next); then compound 2.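

In this assay, swapping one arrangement of these atoms for another on a saturated chain carbon bound to an aromatic carbon gives no change at the digits printed from compound 1 to compound 3 (within the scatter). Among the compounds shown here, this is the first pair here that differs in only one place, so the comparison can be tied to that single group. The group that enters has 1 hydrogen-bond donor and the group that leaves has 0 hydrogen-bond donors, yet the same atoms joined in these two ways give numbers that lie within the scatter of each other, and nothing available explains this result.

Going by these compounds, one rearrangement at one position is a narrow test, so it remains open whether the same swap would give a similarly small step on the core of compound 2, which differs from compound 1 in more than one place. On these data alone, it also remains open how the free fraction would respond to a group of a different kind on this carbon, such as an amine or a longer chain, since both groups compared here have the same atoms.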